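Putting a Pyrazine Ring on the Amide Nitrogen

This account rests on a few compounds, and the source may have more. Where it says the series, first, only, none or still open, it means among the compounds named here.

Compound 1 `O=C(Nc1ccc(Cl)cc1)c1c(O)c2cccnc2n(-c2ccccc2)c1=O`: 2.5%
Compound 2 `COc1cccc(NC(=O)c2c(O)c3cccnc3n(-c3ccccc3)c2=O)c1`: 20.7%
Compound 3 `Cc1ccccc1NC(=O)c1c(O)c2cccnc2n(-c2ccccc2)c1=O`: 9.8%

In a functional assay on the whole organism for inhibition, with Rattus norvegicus as the target, read by cytopathic effect and paw edema, at a dose of 100 mg/kg by the oral route (on this read-out higher numbers stand for more inhibition at the one dose given (going by the name of the read-out) and lower numbers for less inhibition), compound 3 gives 9.8%, the second highest of the three measured numbers; compound 1 sits within the scatter of it, while compound 2 stands beyond the scatter above it. Compound 4 `O=C(Nc1cnccn1)c1c(O)c2cccnc2n(-c2ccccc2)c1=O` differs from compound 3 in one place: pyrazin-2-yl in place of 2-methylphenyl on an amide-type nitrogen. Among the measured compounds shown here, two measured steps touch this same nitrogen, each exchanging one substituted phenyl for another: a number 7.3 percentage points higher from compound 1 to compound 3 (within the scatter) and a number 10.9 percentage points lower from compound 2 to compound 3 (beyond the scatter). Neither step brings in a heteroaromatic ring, and the direction of a move to pyrazin-2-yl is therefore not shown by any measured pair; the values only show how far aryl exchanges on this nitrogen have shifted the read-out. Compound 4 is expected to stay in that range, near 10% (from 0% to 28%). This estimate means a number 0.2 percentage points higher from compound 3 to compound 4 (within the scatter), a step expected to lie within the scatter.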

Compound 4, a percentage reported as inhibition, in the whole organism at one dose (the size of the read-out at that dose, not a potency): 21.2%
The estimate for compound 4 lay 11.2 percentage points below the measured number; the range from low to high includes it.
By their numbers in this assay, from the lowest: compounds 1 and 3 (each within the scatter of the next); then compounds 2 and 4 (each within the scatter of the next).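

Pyrazin-2-yl is the only ring on this amide-type nitrogen that carries hetero atoms, and it gives a number 11.4 percentage points higher from compound 3 to compound 4 (beyond the scatter) and a number 18.7 percentage points higher from compound 1 to compound 4 (beyond the scatter). Set against the 3-methoxyphenyl group, it shows a number 0.5 percentage points higher from compound 2 to compound 4 (within the scatter), so a carbon-only ring is not needed here for inhibition to match that of compound 2. No measurement on hand accounts for this result. Still open, from the compounds shown here alone, is how pyridin-2-yl or plain phenyl on this nitrogen would compare with pyrazin-2-yl. Also open, going by these compounds, is whether an amine or a carboxylic acid on the pyrazin-2-yl ring would keep this inhibition.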